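The source may report more compounds than this note shows. Statements on the series, on what has been measured and on what is new or still open speak of the compounds shown alone.

Three compounds share one core. Compound 1 `COc1cccc(-c2c(-c3ccccc3)c(-c3ccccc3)n3ccc(C#N)cc23)c1` was tested in an assay for inhibition of Polyunsaturated fatty acid lipoxygenase ALOX15 (Oryctolagus cuniculus) (on this read-out lower numbers stand for stronger inhibition and higher numbers for weaker inhibition), and compound 1 gives "not determined" (no result reported). Compound 3 `N#Cc1ccn2c(-c3ccccc3)c(-c3ccccc3)c(OCc3ccc(Cl)cc3)c2c1` was tested in this assay and compound 3 gives "not determined" (no result reported), so compound 3 stands without a value of its own. Compound 2 `N#Cc1ccn2c(-c3ccccc3)c(-c3ccccc3)c(OCOCc3ccccc3)c2c1` did give a result: in this assay compound 2 gives 39000 nM, which is weak inhibition. The unmeasured compound 4 `N#Cc1ccn2c(-c3ccccc3)c(-c3ccccc3)c(C(O)c3ccccc3)c2c1` differs from compound 3 in one place: hydroxy(phenyl)methyl in place of (4-chlorobenzyl)oxy on an aromatic carbon. With no number for compound 3, the size and direction of this step cannot be read from the data, and nothing beyond the usual scatter is expected in either direction. Because compound 2 gives 39000 nM, compound 4 is expected to be similarly weak, estimated at 30000 nM, with a range from 8000 nM to 100000 nM.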

Compound 4, half-maximal inhibitory concentration: 48000 nM
Compound 4: middle estimate off by 1.6-fold (0.20 log units), on the low side; measured number inside the range.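

In this assay the swap of (benzyloxy)methoxy for hydroxy(phenyl)methyl on this aromatic carbon gives a 1.2-fold higher number from compound 2 to compound 4 (0.09 log units; within the scatter) and so does not separate these two groups. Going by these compounds alone, both compounds remain weak inhibitors, and this is the only step at this position that can be read; those involving compound 1 and compound 3 cannot. As far as these compounds go, whether an amine or a carboxylic acid on this carbon would shift the number stays open, as does the effect of removing the phenyl ring from the side group. No measurement shown explains why the two groups give such similar numbers.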